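Replacing Hydroxymethyl with 2-(Trifluoromethyl)phenyl: Expecting Compound 4

A few compounds are considered here, and "the series" means these few. Any claim that something is new, unique, unknown or untested is made for them only; others in the source may bear on it.

Compound 1 `CCCCc1cn(C(c2ccccc2)c2cc3cc(Br)ccc3nc2OC)nn1` gives 5.46% in an ADME assay on PANC-1 cells (Homo sapiens) for cytotoxicity, read by sulforhodamine B assay, with a stated time of 48 h, tested at 10 uM; a lower number here means less inhibition, a higher number more inhibition at the concentration tested (going by the name of the read-out).
Compound 2 `COc1nc2ccc(Br)cc2cc1C(c1ccccc1)n1cc(CCO)nn1` gives 19.8% in this assay.
Compound 3 `COc1nc2ccc(Br)cc2cc1C(c1ccccc1)n1cc(CO)nn1` gives 15% in this assay.

Compound 3 holds the second highest of the three numbers, yet it sits within the scatter of both neighbours: a number 4.8 percentage points lower from compound 2 to compound 3 (within the scatter) and a number 9.5 percentage points higher from compound 1 to compound 3 (within the scatter). Among the measured compounds shown here, only one measured step exceeds the scatter, a number 14.3 percentage points higher from compound 1 to compound 2 (beyond the scatter), and it concerns a small change on a saturated chain. Compound 4 `COc1nc2ccc(Br)cc2cc1C(c1ccccc1)n1cc(-c2ccccc2C(F)(F)F)nn1` differs from compound 3 by 2-(trifluoromethyl)phenyl in place of hydroxymethyl on an aromatic carbon. For the measured compounds named here, no measured step involves an aromatic ring entering at this position, so the earlier steps give little guidance; they suggest that modest changes at this carbon stay within the scatter. Compound 4 is therefore expected to give 15%, with a range from 0% to 38%, an estimated step of no change at the digits printed from compound 3 to compound 4 (within the scatter).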

Compound 4, a percentage reported as inhibition, at one concentration (the size of the read-out at that concentration, not a potency): 11.4%
Beside the measured number, compound 4's estimate is 3.6 percentage points above it; the range from low to high includes it.
By their numbers in this assay, from the lowest: compounds 1, 4, 3 and 2 (each within the scatter of the next, the first and the last beyond it).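

In this assay, 2-(trifluoromethyl)phenyl, with its 10 heavy atoms and six-membered aromatic ring, can stand on this aromatic carbon with the reading staying within the scatter of compound 3, a number 3.6 percentage points lower from compound 3 to compound 4 (within the scatter). The comparisons with the two other chains also stay within the scatter, a number 8.4 percentage points lower from compound 2 to compound 4 (within the scatter) and a number 5.9 percentage points higher from compound 1 to compound 4 (within the scatter), so an aromatic ring at this carbon does not separate compound 4 from any of the three. No measurement here offers an explanation for this result. Still open, going by these compounds, is whether an amine or a carboxylic acid on this carbon would shift the reading beyond the scatter.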